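Methoxy in place of hydrogen on two cores

The source may report more compounds than this note shows. Statements on the series, on what has been measured and on what is new or still open speak of the compounds shown alone.

Compound 1 `Cc1[nH]c2ccccc2c(=O)c1Cc1ccccc1` is the simplest member of this set. In a physicochemical assay for lipophilicity, at pH 7.4 (a higher number here means a more lipophilic compound, a lower number a more polar compound), compound 1 gives 1.93. Compound 3 `CCCCC#Cc1c(C)[nH]c2ccccc2c1=O` carries a different core; the difference between the two cores is not broken down here. In this assay compound 3 gives 5.44, and compound 2 `CCCCC#Cc1c(C)[nH]c2ccc(OC)cc2c1=O` gives 5.25. Compound 1 therefore stands lowest of the three measured numbers, with compound 2 nearest and compound 3 furthest, both gaps beyond the scatter.

The change from compound 3 to compound 2 is methoxy in place of hydrogen on an aromatic carbon, and it made a step of a number 0.19 log units lower from compound 3 to compound 2 (within the scatter). Compound 4 `COc1ccc2c(=O)c(Cc3ccccc3)c(C)[nH]c2c1` has not been measured. It arises from compound 1 by methoxy in place of hydrogen on an aromatic carbon, the same change, at a place described in the same words.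

Going by the values given here, for compound 4 a step of a number 0.18 log units lower from compound 1 to compound 4 (within the scatter) is expected, close to the earlier one, because a number 0.19 log units lower from compound 3 to compound 2 (within the scatter) is the only measured instance of this change and lies within the scatter. Whether a change measured once on one core carries over to another core cannot be settled from three compounds, so the range around the expectation is kept wide. In this assay compound 4 is estimated at 1.75, with the likely span from 1.3 to 2.2.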

Compound 4, distribution coefficient: 2.52
The estimate for compound 4 lay 0.77 log units below the measured number; the whole stated range lies below it.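

In this assay, methoxy in place of hydrogen on an aromatic carbon gave a number 0.59 log units higher from compound 1 to compound 4 (beyond the scatter) on the core of compound 1, against a number 0.19 log units lower from compound 3 to compound 2 (within the scatter) on the core of compound 3. Going by these compounds alone, one step thus lies beyond the scatter and the other within it, which shows that the size of the step did not carry from one core to the other, and that the single step on the core of compound 3 was a poor guide for the core of compound 1. This rests on one pair per core and does not show a rule for other cores, nor does any measurement at hand bear on what lies behind the difference between the two steps.

Open, as far as these compounds go, is how an amine, a carboxylic acid or a longer alkoxy chain in place of the methoxy would read in this assay on either core, and whether such replacements would also give different steps on the two cores. Also open, from the compounds shown here alone, is how methoxy would read on the other aromatic carbons of the core of compound 1, and whether a third core would follow either pair.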